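Removing the Benzyl Ester from Compound 1

The compounds below may be only part of what the source reports. "The series", "measured", "known", "first", "only" and "open" are said of these compounds alone.

Compound 1 `C[C@@H](O)[C@H](NC(=O)CN(c1nc(Cl)nc2[nH]cnc12)C1CC1)C(=O)OCc1ccccc1` gives 29.9% in a functional assay on the whole organism (Tail, strain ICR) with Mus musculus as the target, in the tail flick test, with a stated time of 90 min, at a dose of 25 umol/kg by the oral route (a higher number here means a stronger effect of the compound at the dose given, a lower number a weaker effect), the second highest of the three numbers measured. Compound 2 `O=C(CN(c1nc(Cl)nc2[nH]cnc12)C1CC1)N[C@@H](CC(=O)OCc1ccccc1)C(=O)OCc1ccccc1` gives 15.6%, and compound 3 `O=C(CN(c1nc(Cl)nc2[nH]cnc12)C1CC1)N[C@@H](CCC(=O)OCc1ccccc1)C(=O)OCc1ccccc1` gives 50%. All measured steps alter the group on the saturated chain carbon bound to an amide-type nitrogen and a carbonyl carbon: a number 14.3 percentage points lower from compound 1 to compound 2 (beyond the scatter), a number 20.1 percentage points higher from compound 1 to compound 3 (beyond the scatter) and a number 34.4 percentage points higher from compound 2 to compound 3 (beyond the scatter). Compound 4 `C[C@@H](O)[C@H](NC(=O)CN(c1nc(Cl)nc2[nH]cnc12)C1CC1)C(=O)O` differs from compound 1 at another place: hydrogen in place of benzyl on an oxygen next to a carbonyl group. Among the measured compounds shown here, no measured step alters that oxygen, so the three pairs give no direct guide to the size or direction of this change. The expectation is therefore a step no larger than the scatter, or a modest fall, a number 9.9 percentage points lower from compound 1 to compound 4 (within the scatter). Compound 4 is estimated to give 20%, with a range from 5% to 40%.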

Compound 4, a percentage reported as activity, at one dose (the size of the read-out at that dose, not a potency): 35.9%
Compound 4: the middle estimate sits 15.9 percentage points below what was measured, and the stated range covers the measured number.
By their numbers in this assay, from the lowest: compound 2; then compounds 1 and 4 (each within the scatter of the next); then compound 3.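

In this assay, hydrogen in place of benzyl on an oxygen next to a carbonyl group gives a number 6 percentage points higher from compound 1 to compound 4 (within the scatter). So, for this pair, the read-out at this dose does not depend on the benzyl group, and the carboxy form holds the level of the benzyloxycarbonyl form. Nothing available explains this result.

Still open, from the compounds shown here alone, is whether a methyl ester or a primary amide at this place would read the same. Also open, going by these compounds, is whether losing benzyl from the esters of compound 3 would leave its number unchanged.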